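Removing the sulfamoyl group: expected cytotoxicity of compound 4

The compounds below may be only part of what the source reports. "The series", "measured", "known", "first", "only" and "open" are said of these compounds alone.

Compound 1, `Cc1cc(/C=C/C#N)cc(C)c1Oc1nc(Nc2ccc(N3CCN(S(N)(=O)=O)CC3)cc2)nc2ccsc12`: in an ADME assay on MT4 cells (Homo sapiens) for cytotoxicity, read by MTT assay, with a stated time of 5 days (on this read-out lower numbers stand for higher toxicity in this test and higher numbers for lower toxicity in this test), compound 1 reaches only the assay limit, > 222000 nM.
Compound 2, `Cc1cc(/C=C/C#N)cc(C)c1Oc1nc(Nc2ccc(CN3CCN(S(N)(=O)=O)CC3)cc2)nc2ccsc12`: in this assay compound 2 gives 145000 nM.
Compound 3, `Cc1cc(/C=C/C#N)cc(C)c1Oc1nc(Nc2ccc(N3CCN(S(N)(=O)=O)CC3)cc2)nc2sccc12`: in this assay compound 3 reaches only the assay limit, > 222000 nM.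

Compound 3 thus stands at the limit of > 222000 nM in this assay, at which 2 of the 3 values shown sit. Within the data shown here, the one measured step, an at least 1.5-fold lower number from compound 1 to compound 2 (0.18 log units; that floor lies within the scatter), has a floor that lies within the scatter. Compound 4, `Cc1cc(/C=C/C#N)cc(C)c1Oc1nc(Nc2ccc(N3CCNCC3)cc2)nc2sccc12`, differs from compound 3 by hydrogen in place of sulfamoyl on an amine nitrogen in a ring. Among the measured compounds shown here, no measured step involves this change, so none of them bears on it, and with two values at the limit and compound 2 giving a number, a step beyond the scatter in this assay is not expected. Compound 4 is therefore expected to give 222000 nM, between 110000 nM and 450000 nM. This corresponds to an expected step of a number no higher from compound 3 to compound 4 (the limit leaves the size open).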

Compound 4, half-maximal cytotoxic concentration: 4740 nM
Beside the measured number, compound 4's estimate is 47-fold (1.67 log units) above it; the whole stated range lies above it.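

Replacing sulfamoyl with hydrogen on the amine nitrogen in the ring gives an at least 46-fold lower number from compound 3 to compound 4 (1.67 log units; beyond the scatter) in this assay, which means higher toxicity in this test. The earlier compounds all carried sulfamoyl, and their one step had a floor within the scatter; this is the first step shown to lie beyond it. The printed size is only a floor, because compound 3 stands at a limit: the limit of > 222000 nM in this assay, at which 2 of the 4 values shown sit.

The compounds shown leave open whether an acetyl or a methyl group on that nitrogen would give a high number like sulfamoyl or a low one like hydrogen. They also leave open whether the same change on the core of compound 1 gives a step of similar size.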